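Swapping the Oxetanyloxy Group for a Chloropyrimidine Ring

A few compounds are considered here, and "the series" means these few. Any claim that something is new, unique, unknown or untested is made for them only; others in the source may bear on it.

Compound 1 `Cc1nc(S(C)(=O)=O)ccc1Oc1ncnc(OC2CCN(C(=O)OC(C)(C)C#N)CC2)c1F` gives 1320 nM in a functional assay on isolated protein for inhibition of Glucose-dependent insulinotropic receptor (Rattus norvegicus), read by HTRF and cAMP accumulation; on this read-out higher numbers stand for an effect only at larger amounts of compound and lower numbers for an effect already at smaller amounts.
Compound 2 `Cc1nc(S(C)(=O)=O)ccc1Oc1ncnc(OC2CCN(C(=O)OC3COC3)CC2)c1F` gives 2500 nM in this assay.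
Compound 3 `Cc1nc(S(C)(=O)=O)ccc1Oc1ncnc(OC2CCN(C(=O)C3CCCC3)CC2)c1F` gives 407 nM in this assay.

Among these three, compound 2 stands highest: a 1.9-fold higher number from compound 1 to compound 2 (0.28 log units; within the scatter), whereas a 6.1-fold lower number from compound 2 to compound 3 (0.79 log units; beyond the scatter). Compound 4 `Cc1nc(S(C)(=O)=O)ccc1Oc1ncnc(OC2CCN(C(=O)c3ncc(Cl)cn3)CC2)c1F` is not yet measured; it differs from compound 2 in one place: 5-chloropyrimidin-2-yl in place of (oxetan-3-yl)oxy on a carbonyl carbon. The step that bears most on this change is a 6.1-fold lower number from compound 2 to compound 3 (0.79 log units; beyond the scatter), where a carbon ring likewise took the place of the oxetanyloxy group on the carbonyl carbon; a 3.2-fold lower number from compound 1 to compound 3 (0.51 log units; beyond the scatter) points the same way. A ring directly on the carbonyl carbon is therefore expected to give a modestly lower number, a 4.2-fold lower number from compound 2 to compound 4 (0.62 log units; beyond the scatter). For compound 4 the estimate is 600 nM, expected to fall between 200 nM and 1800 nM.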

Compound 4, half-maximal effective concentration: 30.9 nM
Compound 4: middle estimate off by 19-fold (1.29 log units), on the high side, and the stated range ends above it.
By their numbers in this assay, from the lowest: compound 4; then compound 3; then compounds 1 and 2 (each within the scatter of the next).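

In this assay, going by these compounds alone, the group on this carbonyl carbon matters far more than the earlier compounds showed: 5-chloropyrimidin-2-yl in place of the oxygen-linked groups gives an 81-fold lower number from compound 2 to compound 4 (1.91 log units; beyond the scatter) and a 43-fold lower number from compound 1 to compound 4 (1.63 log units; beyond the scatter). A ring on the carbonyl carbon is not the whole story, as swapping cyclopentyl for the six-membered aromatic ring still gives a 13-fold lower number from compound 3 to compound 4 (1.12 log units; beyond the scatter). Nothing measured here explains this gain.

From the compounds shown here alone, how a plain pyrimidin-2-yl or a phenyl group would compare at this place remains open. The shares of the chlorine and the ring nitrogens in the gain therefore cannot be told apart.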